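The source may report more compounds than this note shows. Statements on the series, on what has been measured and on what is new or still open speak of the compounds shown alone.

Measured in a functional assay on K562 cells (Homo sapiens) for antiproliferative activity, read by MTT assay, with a stated time of 72 h; on this read-out lower numbers stand for stronger inhibition and higher numbers for weaker inhibition:
- Compound 1 `COc1cc(-c2ncnn2-c2ccc(F)cc2)cc(OC)c1OC`: > 10000 nM (a limit)
- Compound 2 `COc1cc(-c2ncnn2-c2ccccc2)cc(OC)c1OC`: > 10000 nM (a limit)

Compound 2 has no numerical value, and its position is defined by the limit of > 10000 nM in this assay, at which 2 of the 2 values shown sit. The next compound, compound 3 `COc1ccc(-n2ncnc2-c2cc(OC)c(OC)c(OC)c2)cc1`, has methoxy in place of hydrogen on an aromatic carbon, para to a large group: methoxy in place of hydrogen on an aromatic carbon. The same difference reads phenyl to 4-methoxyphenyl.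

Going by the values given here, only one measured step bears on this change: a step that the two limits leave unreadable from compound 1 to compound 2. It involves hydrogen in place of fluoro on an aromatic carbon, but it gives no size to carry over. The expectation for compound 3 is therefore loosely constrained and rests on the structural change alone. Any readable value for compound 3 would mean stronger inhibition than compound 2 shows, while a result at the same limit remains quite possible. The expected change is an at least 5.0-fold lower number from compound 2 to compound 3 (0.69 log units; beyond the scatter), towards stronger inhibition. For compound 3 the estimated value is 2000 nM, with an expected range of 100 nM to 10000 nM.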

Compound 3, half-maximal inhibitory concentration: 3600 nM
The estimate for compound 3 lay 1.8-fold (0.26 log units) below the measured number, and the stated range covers the measured number.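

In this assay, going by these compounds alone, this position, para to a large group, is the first place where a change yields a readable number: phenyl to 4-methoxyphenyl gives an at least 2.7-fold lower number from compound 2 to compound 3 (0.44 log units; beyond the scatter). Methoxy in place of fluoro at the same position gives an at least 2.7-fold lower number from compound 1 to compound 3 (0.44 log units; beyond the scatter), so both neighbours of compound 3 show the same direction, and each step is only a minimum size. The step between compound 1 and compound 2 cannot be read, so fluoro and hydrogen at this position cannot be ordered: the limit of > 10000 nM in this assay, at which 2 of the 3 values shown sit.

From the compounds shown here alone, it remains open how large the methoxy step really is, and whether a readable number is particular to methoxy or would also follow from a hydroxy, ethoxy or dimethylamino group at this position. Going by these compounds, it is equally open whether methoxy on another carbon of that ring would give any readable number in this assay.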